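Swapping One Bicyclic Group for Its Isomer

The source may report more compounds than this note shows. Statements on the series, on what has been measured and on what is new or still open speak of the compounds shown alone.

In a physicochemical assay for solubility, read by HPLC, in simulated intestinal fluid, with a stated time of 16 h, tested at 125 ug/mL (on this read-out higher numbers stand for higher solubility and lower numbers for lower solubility), compound 2 `CNC(=O)c1cc(C(=O)NC2CC2)cn(Cc2ccc3nc[nH]c3c2)c1=O` gives 225 ug/mL. Compound 1 `CNC(=O)c1cc(C(=O)NC2CCC2)cn(Cc2cccnc2)c1=O` gives 189 ug/mL, a gap that lies within the scatter, so the two cannot be told apart on this read-out. Compound 3 `CNC(=O)c1cc(C(=O)NC2CC2)cn(Cc2cccc3[nH]ncc23)c1=O` has not been measured; it differs from compound 2 by 1H-indazol-4-yl in place of 1H-benzimidazol-6-yl on a saturated chain carbon bound to an aromatic nitrogen. The two groups match in every count shown, and no measured pair reveals what such a rearrangement does here. A step no larger than the scatter is expected, in either direction, from compound 2 to compound 3, namely a 1.3-fold lower number from compound 2 to compound 3 (0.10 log units; within the scatter). Compound 3 is therefore estimated at 180 ug/mL, between 90 ug/mL and 360 ug/mL.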

Compound 3, solubility: 4 ug/mL
Compound 3: middle estimate off by 45-fold (1.65 log units), on the high side; the measured number lies below the stated range.
By their numbers in this assay, from the lowest: compound 3; then compounds 1 and 2 (each within the scatter of the next).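

On a saturated chain carbon bound to an aromatic nitrogen, 1H-indazol-4-yl in place of 1H-benzimidazol-6-yl gives a 56-fold lower number from compound 2 to compound 3 (1.75 log units; beyond the scatter) in this assay, so this position is far from indifferent to how the same atoms are joined. Matching counts of atoms, donors and acceptors do not settle this read-out here. Nothing available explains the drop. On these data alone, it remains open whether the drop belongs to the indazole itself or to where it is attached. A 1H-indazol-6-yl group on the same carbon would help separate the two.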